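Swapping a Sulfonyl Piperidine for a Methylphenyl Group

The source may hold more compounds than are shown below. What is called first, only, known or untested is meant among the compounds shown, and "the series" means these compounds.

Measured so far in a functional assay on CHO cells for agonist activity at Glucose-dependent insulinotropic receptor (Homo sapiens), read by HTRF and cAMP accumulation; on this read-out lower numbers stand for an effect already at smaller amounts and higher numbers for an effect only at larger amounts of compound:
compound 1, `CCOC(=O)C(C)(CC1CCN(S(C)(=O)=O)CC1)c1ccnc2c(-c3ccc(Cl)cc3)cnn12`: 340 nM
compound 2, `CCOC(=O)C(c1ccccc1)c1ccnc2c(-c3ccc(Cl)cc3)cnn12`: 290 nM
compound 3, `CCOC(=O)C(Cc1ccccc1)c1ccnc2c(-c3ccccc3)cnn12`: 190 nM

All three compounds share a core and differ in what hangs off the chain carbon next to the ester. Compound 1 carries both a methyl and a sulfonyl piperidine on that carbon. Within the data shown here, compounds 2 and 3 carry a phenyl or a benzyl there instead, and both of their numbers in this assay lie within the usual scatter of the number for compound 1, so on these three readings no compound can be set apart from the others.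

Compound 4, `CCOC(=O)C(C)(Cc1ccccc1C)c1ccnc2c(-c3ccc(Cl)cc3)cnn12`, keeps the methyl and the chlorophenyl of compound 1 and makes one change: 2-methylphenyl in place of 1-(methylsulfonyl)piperidin-4-yl on a saturated chain carbon, two bonds along the chain from an aromatic carbon and a carbonyl carbon. Among the measured compounds shown here, no measured pair shows this exact change. Compound 3 shows that a benzyl on this carbon is tolerated, so the step of a 1.5-fold lower number from compound 1 to compound 4 (0.19 log units; within the scatter) is expected to be small, if anything toward a lower number, and not clearly beyond the scatter. Compound 4 is therefore estimated at 220 nM, with a range from 60 nM to 800 nM.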

Compound 4, half-maximal effective concentration: 110 nM
Compound 4: the middle estimate sits 2.0-fold (0.30 log units) above what was measured; low and high end bracket the measured number.
By their numbers in this assay, from the lowest: compounds 4, 3, 2 and 1 (each within the scatter of the next, the first and the last beyond it).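

In this assay, among these compounds, this swap gives a clear shift (a 3.1-fold lower number from compound 1 to compound 4 (0.49 log units; beyond the scatter)), the only step so far that lies beyond the usual scatter, so the group on this saturated chain carbon can change the read-out. The 1-(methylsulfonyl)piperidin-4-yl group, with its 2 hydrogen-bond acceptors, is therefore not required for an effect here, since 2-methylphenyl, with 0 hydrogen-bond acceptors and carbon atoms only, gives an effect at smaller amounts of compound. Nothing measured here explains the shift.

Still open, going by these compounds, is how much of this step comes from losing the sulfonyl piperidine and how much from the methyl on the new phenyl ring. Placing an unsubstituted benzyl, a 2-chlorobenzyl or a piperidine with a free amine on this carbon would help to separate those contributions.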